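A few compounds are considered here, and "the series" means these few. Any claim that something is new, unique, unknown or untested is made for them only; others in the source may bear on it.

Compound 3 `CONC(=S)N/N=C1\C(=O)N(CN2CCN(c3ccc(Cl)cc3)CC2)c2ccc(F)cc21` and compound 1 `CONC(=S)N/N=C1\C(=O)N(CN2CCN(c3ccc(Cl)cc3)CC2)c2ccc(Cl)cc21` share one core and differ in a single spot: chloro in place of fluoro on an aromatic carbon. In an ADME assay on MT4 cells (Homo sapiens) for cytotoxicity, read by spectrophotometry, with a stated time of 5 days (a higher number here means that more compound is tolerated, a lower number that less compound is tolerated), compound 3 gives 347000 nM, and compound 1 gives 229000 nM; the step between them is a 1.5-fold lower number from compound 3 to compound 1 (0.18 log units; within the scatter), so no real difference in tolerated concentration can be read from this swap.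

Compound 2 `CCn1cc(C(=O)O)c(=O)c2cc(F)c(N3CCN(CN4C(=O)/C(=N\NC(=S)NO)c5cc(F)ccc54)CC3)cc21` is built on a different core; the difference between the two cores is not broken down here. In this assay compound 2 gives 208000 nM, a number within the scatter of both compound 1 and compound 3, so no order among the three compounds can be stated.

Compound 4 `CCn1cc(C(=O)O)c(=O)c2cc(F)c(N3CCN(CN4C(=O)/C(=N\NC(=S)NO)c5cc(Cl)ccc54)CC3)cc21` carries the same change, now made on the core of compound 2: chloro in place of fluoro on an aromatic carbon. Going by the values given here, the leaving group, the entering group and the place match those of the earlier pair exactly, so the same change is involved, and the earlier pair is the only guide to its size. For compound 4 the expected step is a 1.2-fold lower number from compound 2 to compound 4 (0.09 log units; within the scatter), because a 1.5-fold lower number from compound 3 to compound 1 (0.18 log units; within the scatter) shows the swap moved the number only within the scatter. Compound 4 is therefore expected to give about 170000 nM, within an estimated range from 90000 nM to 320000 nM. A single earlier pair is a thin basis, and a different core need not respond alike, so the range is kept wide.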

Compound 4, half-maximal cytotoxic concentration: 186000 nM
The estimate for compound 4 lay 1.1-fold (0.04 log units) below the measured number; the range from low to high includes it.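

In this assay, the swap of fluoro for chloro on the core of compound 2 gives a 1.1-fold lower number from compound 2 to compound 4 (0.05 log units; within the scatter) and so leaves no real difference in tolerated concentration. Set side by side, the two cores show the same picture, with neither step standing out from the usual spread of repeated measurements: the same change on two cores in this assay, a 1.5-fold lower number (0.18 log units; within the scatter) from compound 3 to compound 1 and a 1.1-fold lower number (0.05 log units; within the scatter) from compound 2 to compound 4, 1.4-fold (0.13 log units) apart, within the scatter of two such steps. This supports carrying the swap between these two cores only in a modest sense: on both, the exchange of one halogen for the other left the number where repeat measurements could have put it, but two steps this small cannot show that the cores respond identically, nor reveal any small effect hidden inside the scatter.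

The compounds shown leave open whether a group other than fluoro or chloro on that aromatic carbon, such as bromo, methoxy or nitrile, would shift the number beyond the scatter, which would give a much sharper test of whether a change carries over from one core to the other. Going by these compounds alone, they also leave open how the chloro-for-fluoro swap would behave on a third core, since only two cores appear here.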